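A few compounds are considered here, and "the series" means these few. Any claim that something is new, unique, unknown or untested is made for them only; others in the source may bear on it.

Compound 1 `CCCCCOc1ccc(C(=O)N(C(=S)OCCN2C(=O)c3ccccc3C2=O)c2ccc(F)cc2)cc1` gives in an ADME assay on MT4 cells (Homo sapiens) for cytotoxicity, read by MTT assay (on this read-out lower numbers stand for higher toxicity in this test and higher numbers for lower toxicity in this test), a limit of the assay rather than a number, > 100000 nM.
Compound 2 `O=C1c2ccccc2C(=O)N1CCOC(=S)N(C(=O)c1cccc(Cl)c1Cl)c1ccc(Cl)cc1` gives in this assay 54000 nM.
Compound 3 `Cc1ccc(N(C(=O)c2cccc(Cl)c2Cl)C(=S)OCCN2C(=O)c3ccccc3C2=O)cc1` gives in this assay 35000 nM.

Among the two numbers shown, compound 2 holds the higher one, but its nearest neighbour lies a 1.5-fold lower number from compound 2 to compound 3 (0.19 log units; within the scatter), so the two cannot be told apart. Compound 4 `O=C1c2ccccc2C(=O)N1CCOC(=S)N(C(=O)c1cccc2ccccc12)c1ccc(Cl)cc1` differs from compound 2 in one place: naphthalen-1-yl in place of 2,3-dichlorophenyl on a carbonyl carbon. Going by the values given here, the only measured step, a 1.5-fold lower number from compound 2 to compound 3 (0.19 log units; within the scatter), concerns a different group at a different place and offers no direct guide to this change. With nothing in the data pointing either way, the step of a 1.2-fold lower number from compound 2 to compound 4 (0.08 log units; within the scatter) is expected to remain within the scatter of the value of compound 2. Compound 4 is therefore estimated at 45000 nM, with a likely range from 15000 nM to 140000 nM.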

Compound 4, half-maximal cytotoxic concentration: 6000 nM
Compound 4: the middle estimate sits 7.5-fold (0.88 log units) above what was measured, and the stated range ends above it.
By their numbers in this assay, from the lowest: compound 4; then compounds 3 and 2 (each within the scatter of the next). At a limit, above all of these: compound 1.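

Putting naphthalen-1-yl in place of 2,3-dichlorophenyl on the carbonyl carbon gives a 9.0-fold lower number from compound 2 to compound 4 (0.95 log units; beyond the scatter) in this assay, so a lower number here means higher toxicity in this test. Going by these compounds alone, the earlier compounds offered only a step at another place, a 1.5-fold lower number from compound 2 to compound 3 (0.19 log units; within the scatter), so this is the first clear sign that the group on this carbonyl carbon matters. No measurement shown says what lies behind this step. From the compounds shown here alone, it remains open whether the second aromatic ring or the loss of the two chlorines matters more, and an unsubstituted phenyl on this carbonyl would help separate the two.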